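Series notes: adding allylsulfanyl back onto compound 2

The source may hold more compounds than are shown below. What is called first, only, known or untested is meant among the compounds shown, and "the series" means these compounds.

Measured so far:
compound 1 `Cc1ccc(CSc2nc3nc(C)cc(Nc4cc(-c5ccccc5)[nH]n4)n3n2)cc1` — 6960 nM
compound 2 `Cc1cc(Nc2cc(-c3ccccc3)[nH]n2)n2ncnc2n1` — 21700 nM
compound 3 `Cc1cc(Nc2cc(-c3ccc(F)cc3)[nH]n2)n2nc(SCc3ccc(Br)cc3)nc2n1` — 2210 nM

In a functional assay on MGC-803 cells (Homo sapiens) for inhibition, read by MTT assay, with a stated time of 72 h (on this read-out higher numbers stand for weaker inhibition and lower numbers for stronger inhibition), compound 2 gives 21700 nM, the highest of the three numbers. Going by the values given here, compound 1 gives 6960 nM and compound 3 gives 2210 nM; compound 3 differs from compound 2 in two places, so no single step links them.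

Compound 4 `C=CCSc1nc2nc(C)cc(Nc3cc(-c4ccccc4)[nH]n3)n2n1` is not yet measured. Its change from compound 2: allylsulfanyl in place of hydrogen on an aromatic carbon.

Among the compounds with values here, the only step that bears on this change is a 3.1-fold higher number from compound 1 to compound 2 (0.49 log units; beyond the scatter), a modest but real rise on removing a sulfanyl group from the same place. Restoring a sulfanyl group there is therefore expected to lower the number, with a step of roughly that size or somewhat smaller, since the entering group is not the one removed.

Compound 4 is expected to give about 9000 nM (range 4000 nM to 20000 nM), an expected step of a 2.4-fold lower number from compound 2 to compound 4 (0.38 log units; beyond the scatter).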

Compound 4, half-maximal inhibitory concentration: 17200 nM
The estimate for compound 4 lay 1.9-fold (0.28 log units) below the measured number, and the stated range covers the measured number.
By their numbers in this assay, from the lowest: compound 3; then compound 1; then compounds 4 and 2 (each within the scatter of the next).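

In this assay, allylsulfanyl on this aromatic carbon is not separated from hydrogen (a 1.3-fold lower number from compound 2 to compound 4 (0.10 log units; within the scatter)), so a sulfanyl link alone does not reproduce the step seen with (4-methylbenzyl)sulfanyl. What stands on the sulfur counts here, as the vinyl in place of 4-methylphenyl on the saturated chain carbon gives a real change (a 2.5-fold higher number from compound 1 to compound 4 (0.39 log units; beyond the scatter)). Nothing available explains this difference.

The compounds shown leave open whether a plain benzyl group on the sulfur would match compound 1. They also leave open how an amine or a longer chain there would read.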